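A Nitro Group Carried Over to a Second Core

This account rests on a few compounds, and the source may have more. Where it says the series, first, only, none or still open, it means among the compounds named here.

Compound 1 `CCn1cc(-c2nc3ccccc3[nH]2)c(=O)c2cc(F)c(N3CCNCC3)cc21`: 27400 nM
Compound 2 `CCn1cc(-c2nc3ccccc3[nH]2)c(=O)c2cc(F)c(N3CCNC(C)C3)c(F)c21`: 30200 nM
Compound 3 `CCn1cc(-c2nc3ccc([N+](=O)[O-])cc3[nH]2)c(=O)c2cc(F)c(N3CCNCC3)cc21`: 2100 nM

All three were tested in a functional assay on Bel-7402 cells (Homo sapiens) for cytotoxicity, read by MTT assay, with a stated time of 48 h; on this read-out lower numbers stand for stronger inhibition and higher numbers for weaker inhibition. Compound 1 and compound 2 share much of their structure, but the difference between the two cores is not broken down here; their numbers in this assay lie within the scatter of each other, so nothing can be said about their order. Compound 3 carries a nitro group where compound 1 carries hydrogen: nitro in place of hydrogen on an aromatic carbon. That one change gave a 13-fold lower number from compound 1 to compound 3 (1.12 log units; beyond the scatter).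

Compound 4 `CCn1cc(-c2nc3ccc([N+](=O)[O-])cc3[nH]2)c(=O)c2cc(F)c(N3CCNC(C)C3)c(F)c21` has not yet been measured. It carries the same change on the core of compound 2: nitro in place of hydrogen on an aromatic carbon. The place is the same word for word, so this is the same change. A step of similar size is expected, a 12-fold lower number from compound 2 to compound 4 (1.07 log units; beyond the scatter). This expectation rests on a 13-fold lower number from compound 1 to compound 3 (1.12 log units; beyond the scatter). That step was seen once, at the same place. Because that rests on a single pair, the expectation is held loosely. Compound 4 is expected to give about 2600 nM in this assay, most likely between 900 nM and 8000 nM.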

Compound 4, half-maximal inhibitory concentration: 1100 nM
Estimate against measurement, compound 4: 2.4-fold (0.37 log units) above, within the range that was stated.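

On the core of compound 2, nitro in place of hydrogen on an aromatic carbon gave a 27-fold lower number from compound 2 to compound 4 (1.44 log units; beyond the scatter) in this assay. Set beside the earlier step on the other core, the change points the same way on both, and the two step sizes cannot be told apart: the same change on two cores in this assay, a 13-fold lower number (1.12 log units; beyond the scatter) from compound 1 to compound 3 and a 27-fold lower number (1.44 log units; beyond the scatter) from compound 2 to compound 4, 2.1-fold (0.32 log units) apart, within the scatter of two such steps. This shows that, in this small series, the large effect of the nitro group carried over from one core to the other, but it rests on just two pairs and does not show why the number falls or whether the same would happen on a third core.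

The compounds shown leave open whether another group at the same place, such as an amine, a nitrile or a carboxylic acid, would give a step of similar size. They also leave open which of the differences between the two cores matter, since those cores differ in more than one place.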